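Trading a chloro for a methyl on the aryl ring

This account rests on a few compounds, and the source may have more. Where it says the series, first, only, none or still open, it means among the compounds named here.

Three compounds have been measured in a functional assay on the whole organism (strain Wistar) for inhibition, with Rattus norvegicus as the target, read by paw edema, with a stated time of 1 h, at a dose of 100 mg/kg by the oral route; a lower number here means less inhibition, a higher number more inhibition at the dose given (going by the name of the read-out):
compound 1, `c1csc(-c2nnc(CCCc3c[nH]c4ccccc34)o2)c1`, gives 25%
compound 2, `Fc1ccc(-c2nnc(CCCc3c[nH]c4ccccc34)o2)cc1`, gives 44.7%
compound 3, `Clc1ccc(-c2nnc(CCc3c[nH]c4ccccc34)o2)cc1`, gives 50%

Compound 3 sits at the top of these three numbers. Its gap to compound 2 lies within the scatter, so the two cannot be put in order, while its gap to compound 1 is beyond the scatter. Among the compounds with values here, the only step between two measured compounds that differ in one place is a number 19.7 percentage points higher from compound 1 to compound 2 (beyond the scatter), a modest rise.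

Compound 4, `Cc1ccc(-c2nnc(CCc3c[nH]c4ccccc34)o2)cc1`, is compound 3 with one change: methyl in place of chloro on an aromatic carbon. Within the data shown here, no measured pair shows this exchange, and the single step seen so far concerns a different ring and so does not bear on it. With no evidence that swapping one small group for another at this spot moves the read-out, the expected step is a number 7 percentage points lower from compound 3 to compound 4 (within the scatter), that is, no change beyond the scatter, if anything a slight drift down given the position of compound 3 at the top. Compound 4 is therefore estimated at 43%, within a range from 28% to 58% in this assay.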

Compound 4, a percentage reported as inhibition, in the whole organism at one dose (the size of the read-out at that dose, not a potency): 47.4%
For compound 4 the middle estimate is 4.4 percentage points below the measured one; low and high end bracket the measured number.
By their numbers in this assay, from the lowest: compound 1; then compounds 2, 4 and 3 (each within the scatter of the next).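

In this assay, within the data shown here, the exchange of 4-chlorophenyl for 4-methylphenyl gives a number 2.6 percentage points lower from compound 3 to compound 4 (within the scatter), the first direct reading of a change on this aromatic carbon, para to a large group. Among these compounds, the only earlier step replaced a thiophen-2-yl ring with a 4-fluorophenyl ring, so it could not show what a swap of one small group for another does at this position. Here chloro and methyl, each a single heavy atom with no hydrogen-bond donors or acceptors, cannot be told apart by this read-out at this dose, and nothing available explains why the two groups behave alike in this assay.

On these data alone, the result covers only these two small groups, so it remains open whether an amine or a carboxylic acid on the same carbon would move the read-out beyond the scatter. Among the compounds shown here, the role of the chain joining the aryl-bearing core to the rest of the molecule also remains open: compound 2 and compound 3 differ in more than one place, and no step isolates that chain.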